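Swapping an Amine for an Ether on One Core

A few compounds are considered here, and "the series" means these few. Any claim that something is new, unique, unknown or untested is made for them only; others in the source may bear on it.

Of the compounds shown here, three built on one shared core have been tested in a functional assay on DU-145 cells (Homo sapiens) for cytotoxicity, read by MTT assay, with a stated time of 72 h; a lower number here means a stronger inhibitor, a higher number a weaker inhibitor. Compound 1 `CNc1cc2nc(-c3ccccc3)nn(-c3ccccc3)c-2cc1=O` gives 980 nM. Compound 2 `CCNc1cc2nc(-c3ccccc3)nn(-c3ccccc3)c-2cc1=O` gives 220 nM. The two differ only by methyl in place of hydrogen on a saturated chain carbon bound to a nitrogen on an aromatic ring, and that change gave a 4.5-fold lower number from compound 1 to compound 2 (0.65 log units; beyond the scatter). Compound 3 `COc1cc2nc(-c3ccccc3)nn(-c3ccccc3)c-2cc1=O` differs from compound 1 by methoxy in place of methylamino on an aromatic carbon. For compound 3 the assay reports only a limit, > 5000 nM, not a number. The steps of an at least 5.1-fold higher number from compound 1 to compound 3 (0.70 log units; beyond the scatter) and an at least 22-fold higher number from compound 2 to compound 3 (1.35 log units; beyond the scatter) are therefore known only as lower bounds, which rests on (the limit of > 5000 nM in this assay, at which 1 of the 3 values shown sits).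

Compound 4 `CCOc1cc2nc(-c3ccccc3)nn(-c3ccccc3)c-2cc1=O` has not yet been measured. It differs from compound 3 by methyl in place of hydrogen on a saturated chain carbon bound to an oxygen on an aromatic ring. For the measured compounds named here, this is the same kind of change as the one from compound 1 to compound 2, but the place is not the same: there the added methyl sits on a saturated chain carbon bound to a nitrogen on an aromatic ring, here on a saturated chain carbon bound to an oxygen on an aromatic ring. The step expected in this assay is an at least 1.6-fold lower number from compound 3 to compound 4 (0.22 log units; that floor lies within the scatter), set beside the earlier 4.5-fold lower number from compound 1 to compound 2 (0.65 log units; beyond the scatter). Since the starting point is itself a limit, the expectation is loose, and another limit is quite possible. Compound 4 is estimated at about 3000 nM. For compound 4 the expected range runs from 800 nM to 12000 nM.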

Compound 4, half-maximal inhibitory concentration: > 5000 nM
Compound 4 ended at the assay's limit; the forecaster's own chance of this, stated with the estimate: 45%; at least 1.6-fold (0.22 log units) between middle value and limit.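

In this assay compound 4 gives only a limit (> 5000 nM) and not a number. What can be read is the distance to the amines, with an at least 22-fold higher number from compound 2 to compound 4 (1.35 log units; beyond the scatter) and with an at least 5.1-fold higher number from compound 1 to compound 4 (0.70 log units; beyond the scatter) as well, so ethoxy, like methoxy in compound 3, stands apart from both ethylamino and methylamino on this core. Whether the added methyl does on the oxygen what it did on the nitrogen, where it gave a 4.5-fold lower number from compound 1 to compound 2 (0.65 log units; beyond the scatter) in the amine pair, stays unknown: the change neither carries over visibly nor is shown to fail, and the step between compound 3 and compound 4 cannot be read, because both compounds stand at one limit: the limit of > 5000 nM in this assay, at which 2 of the 4 values shown sit.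

The compounds shown leave open whether any ether on this core reaches a true number in this assay, for instance one with a longer chain such as propoxy or a ring such as benzyloxy. On the amine side they leave open whether the trend from methylamino to ethylamino goes on with a longer chain such as propylamino, and how a plain amino group or dimethylamino would compare.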